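This account rests on a few compounds, and the source may have more. Where it says the series, first, only, none or still open, it means among the compounds named here.

Among the measured compounds shown here, compound 2 `CCCC1CCCCC1OCCCCCCN1C[C@H](O)[C@@H](O)[C@H](O)[C@H]1CO` is the only member of the series with a number rather than a limit in an ADME assay on MDBK cells (Bos taurus) for cytotoxicity, read by MTT assay (on this read-out higher numbers stand for lower toxicity in this test and lower numbers for higher toxicity in this test), where compound 2 gives 150000 nM. Compound 1 `COc1ccc(OCCCCCCN2C[C@H](O)[C@@H](O)[C@H](O)[C@H]2CO)cc1` sits at the limit of this assay, (the limit of > 500000 nM in this assay, at which 1 of the 2 values shown sits), so in this assay compound 1 gives > 500000 nM and this is a limit, not a number. For the measured compounds named here, the one measured step, an at least 3.3-fold lower number from compound 1 to compound 2 (0.52 log units; beyond the scatter), replaced an aromatic ring by a non-aromatic one on the same oxygen and went beyond the scatter. Compound 3 `OC[C@@H]1[C@@H](O)[C@H](O)[C@@H](O)CN1CCCCCCOc1c(F)cc(F)cc1F` differs from compound 2 by a group of 9 heavy atoms (6 carbon, 3 fluorine; one six-membered aromatic ring of carbon only) in place of a group of 9 heavy atoms (9 carbon; one six-membered non-aromatic ring of carbon only), on an oxygen on a saturated carbon. This reverses the direction of the measured step, an aromatic ring returning in place of the non-aromatic one, so a move back toward the limit is expected, of a size at least matching the measured step, estimated as a 3.0-fold higher number from compound 2 to compound 3 (0.48 log units; beyond the scatter). Compound 3 is therefore expected to give 450000 nM in this assay, within a range of 150000 nM to 1500000 nM, with a real chance that only a limit is reported.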

Compound 3, half-maximal cytotoxic concentration: > 500000 nM
Compound 3: a limit, no number; the forecaster's own chance of this, stated with the estimate: 45%; middle value at least 1.1-fold (0.04 log units) from the limit.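

In this assay, 2,4,6-trifluorophenyl in place of the non-aromatic ring gives an at least 3.3-fold higher number from compound 2 to compound 3 (0.52 log units; beyond the scatter), so the difference seen with 4-methoxyphenyl is also seen with a second aromatic group on this oxygen, one that carries fluorine rather than oxygen. Compound 3 gives > 500000 nM, which is a limit and not a number. Among the compounds shown, only compound 2, with its non-aromatic ring, has a measured number, and the step between compound 1 and compound 3 cannot be read: the limit of > 500000 nM in this assay, at which 2 of the 3 values shown sit.

From the compounds shown here alone, how the two aromatic groups rank against each other stays open. Going by these compounds, it is also open whether an unsubstituted cyclohexyl group on the same oxygen, or a phenyl ring carrying an amine or a carboxylic acid, would give a number or a limit.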